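Trading an Aryl Group for an Arylamino Group

A few compounds are considered here, and "the series" means these few. Any claim that something is new, unique, unknown or untested is made for them only; others in the source may bear on it.

In a functional assay on HeLa cells (Homo sapiens) for antiproliferative activity, read by MTT assay, with a stated time of 72 h (on this read-out higher numbers stand for weaker inhibition and lower numbers for stronger inhibition), compound 1 `COc1ccc(OC)c(-c2c(C(=O)c3cc(OC)c(OC)c(OC)c3)sc3ccccc23)c1` gives 10000 nM, while compound 2 `CCOc1ccc(-c2c(C(=O)c3cc(OC)c(OC)c(OC)c3)sc3ccccc23)cc1` gives 3000 nM, the lower of the two numbers. Compound 3 `COc1cc(C(=O)c2sc3ccccc3c2Nc2ccc(C)cc2)cc(OC)c1OC` has (4-methylphenyl)amino in place of 4-ethoxyphenyl on an aromatic carbon. Going by the values given here, only one measured step bears on this change: a 3.3-fold lower number from compound 1 to compound 2 (0.52 log units; beyond the scatter), a modest gain that also came from replacing a group on an aromatic carbon. That step brought in no amino group, and neither measured compound has one, so the direction remains uncertain. The expected change in this assay is small: a 1.5-fold lower number from compound 2 to compound 3 (0.18 log units; within the scatter). Compound 3 is estimated at 2000 nM, with an expected range of 300 nM to 10000 nM.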

Compound 3, half-maximal inhibitory concentration: 3500 nM
The estimate for compound 3 lay 1.8-fold (0.24 log units) below the measured number; the measured number falls inside the stated range.
By their numbers in this assay, from the lowest: compounds 2 and 3 (each within the scatter of the next); then compound 1.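

Replacing 4-ethoxyphenyl with (4-methylphenyl)amino on this aromatic carbon gives a 1.2-fold higher number from compound 2 to compound 3 (0.07 log units; within the scatter), so the two groups cannot be told apart here, even though the entering group has a hydrogen-bond donor and the leaving group has none. Replacing 2,5-dimethoxyphenyl with the same group gives a 2.9-fold lower number from compound 1 to compound 3 (0.46 log units; beyond the scatter), a modest step that matches what 4-ethoxyphenyl achieved. No measurement is available to explain these results. The compounds shown leave open what the amino link and the methyl group each contribute, as they enter together. A (4-ethoxyphenyl)amino group would separate the two.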